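This account rests on a few compounds, and the source may have more. Where it says the series, first, only, none or still open, it means among the compounds named here.

Compound 1 `c1ccc(-c2nnc(-c3cn4ccccc4n3)o2)cc1` carries an unsubstituted phenyl group on the shared core. In a functional assay on DU-145 cells (Homo sapiens) for antiproliferative activity, read by MTT assay, with a stated time of 48 h (on this read-out higher numbers stand for weaker inhibition and lower numbers for stronger inhibition), compound 1 gives 23400 nM. Compound 2 `Clc1ccc(-c2nnc(-c3cn4ccccc4n3)o2)cc1` differs from it by chloro in place of hydrogen on an aromatic carbon. In this assay compound 2 gives 32800 nM, so the result is a 1.4-fold higher number from compound 1 to compound 2 (0.15 log units; within the scatter). Compound 3 `Cc1cc(Br)c2nc(-c3nnc(-c4ccccc4)o3)cn2c1` keeps the same phenyl group but sits on a different core, bearing a methyl and a bromine; the difference between the two cores is not broken down here. In this assay compound 3 gives 18900 nM, a number close to that of compound 1 and of compound 2, with nothing to separate the three. Among the compounds with values here, compound 4 `Cc1cc(Br)c2nc(-c3nnc(-c4ccc(Cl)cc4)o3)cn2c1` has not yet been measured; it differs from compound 3 by chloro in place of hydrogen on an aromatic carbon, which is the same change, at the same place, as the one that turned compound 1 into compound 2. Because that earlier change produced a 1.4-fold higher number from compound 1 to compound 2 (0.15 log units; within the scatter), the expected step is only a 1.3-fold higher number from compound 3 to compound 4 (0.12 log units; within the scatter), resting on that single precedent. Compound 4 is therefore estimated to give 25000 nM, most likely between 12000 nM and 50000 nM.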

Compound 4, half-maximal inhibitory concentration: 46000 nM
The estimate for compound 4 lay 1.8-fold (0.26 log units) below the measured number; the range from low to high includes it.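

In this assay, replacing phenyl with 4-chlorophenyl on the core that carries the methyl and the bromine gives a 2.4-fold higher number from compound 3 to compound 4 (0.39 log units; beyond the scatter), a modest step towards weaker inhibition. The same change on the core of compound 1 gave a step that cannot be told apart from this one: the same change on two cores in this assay, a 1.4-fold higher number (0.15 log units; within the scatter) from compound 1 to compound 2 and a 2.4-fold higher number (0.39 log units; beyond the scatter) from compound 3 to compound 4, 1.7-fold (0.24 log units) apart, within the scatter of two such steps. Within the data shown here, the change therefore carries across these two cores with no measurable difference in size, although only the step on the second core stands clear of the scatter, and two pairs cannot show that it would hold on any further core or explain why it occurs.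

The compounds shown leave open how other groups at the same place on the phenyl ring would behave, such as a methoxy group, an amine or a carboxylic acid. Among these compounds, they also leave open what the methyl and the bromine each contribute on their own, as no pair here separates them.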